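A few compounds are considered here, and "the series" means these few. Any claim that something is new, unique, unknown or untested is made for them only; others in the source may bear on it.

Working notes on the series. In a functional assay on Vero cells (Chlorocebus sabaeus) for cytotoxicity (on this read-out lower numbers stand for stronger inhibition and higher numbers for weaker inhibition), compound 1 (`Nc1ccn([C@H]2CC(F)(F)[C@H](CO)O2)c(=O)n1`) reads > 100000 nM, which is a limit of the assay and not a number. Among the measured compounds shown here, compound 2 (`Nc1nc(O)c2ncn([C@@H]3C=C(F)[C@H](CO)O3)c2n1`) gives 36500 nM, the only true number so far in this assay, so it is the single quantified anchor for what follows.

Compound 3 (`Nc1nc(O)c2ncn([C@H]3C=C(F)[C@H](CO)O3)c2n1`) keeps the atoms and bonds of compound 2 and changes only in configuration: the two compounds have the same atoms and bonds and differ only in configuration as drawn: 1 of 2 stereo elements differ; a stereocentre at a saturated ring carbon is drawn S in compound 2 and R in compound 3. For the measured compounds named here, no measured pair shows what such an inversion does, so the size of the step is a judgement and not a reading. With compound 2 at 36500 nM, a small move is the likely outcome. The step expected is a 1.6-fold higher number from compound 2 to compound 3 (0.22 log units; within the scatter), toward weaker inhibition, and a report of only a limit would not be surprising. For compound 3 the estimated value is 60000 nM, with an expected range from 20000 nM to 100000 nM.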

Compound 3, half-maximal inhibitory concentration: > 100000 nM
Compound 3: only a limit was reported; the forecaster's own chance of this, stated with the estimate: 40%; at least 1.6-fold (0.22 log units) between middle value and limit.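

In this assay the series now holds a pair that differs in one place, and the step is an at least 2.7-fold higher number from compound 2 to compound 3 (0.43 log units; beyond the scatter). Among the compounds shown here, the read-out therefore responds to the configuration at this saturated ring carbon, a change the earlier compounds could not show, and the step can be put down to configuration alone because nothing else separates the pair: the fact that compounds 2 and 3 differ only in the configuration as drawn. The step is bounded on one side only, as the result for compound 3 is a limit of the assay and not a number, so it fixes a direction and a smallest size but no true size for this inversion.

Going by these compounds, how far the step reaches stays open, as the true size cannot be read from values that sit at the end of the read-out: the limit of > 100000 nM in this assay, at which 2 of the 3 values shown sit. Also open, on these data alone, are whether the same inversion reads the same way in a compound without the fluorine, and what an amine or a carboxylic acid in place of the fluorine would give in this assay.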